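The compounds below may be only part of what the source reports. "The series", "measured", "known", "first", "only" and "open" are said of these compounds alone.

In an in vivo ADME assay on the whole organism for metabolic stability, with Rattus norvegicus as the target (on this read-out lower numbers stand for a shorter-lived compound and higher numbers for a longer-lived compound), three compounds sharing a common core have been measured. Compound 1 `CC(=O)Nc1ccc(Nc2nc(N)n(-c3ccccn3)n2)cc1` gives 1.33 h, compound 2 `CC(=O)N1CCC(c2ccc(Nc3nc(N)n(-c4ccccn4)n3)cc2)C1` gives 1.42 h, and compound 3 `CN1CCC(c2cccc(Nc3nc(N)n(-c4ccccn4)n3)c2)CC1` gives 2.48 h. These values all lie within the scatter of one another, so compound 3 does not stand apart from the other two.

Compound 4 `Nc1nc(Nc2cccc(C(=O)N3CCOCC3)c2)nn1-c1ccccn1` has not yet been measured, and it differs from compound 3 in one place: (morpholin-4-yl)carbonyl in place of 1-methylpiperidin-4-yl on an aromatic carbon. Here (morpholin-4-yl)carbonyl comes in place of 1-methylpiperidin-4-yl on an aromatic carbon.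

Within the data shown here, only one measured step offers any guide, and only indirectly: a 1.1-fold higher number from compound 1 to compound 2 (0.03 log units; within the scatter). In that step, 1-acetylpyrrolidin-3-yl comes in place of acetamido on an aromatic carbon. Among the measured compounds shown here, it stays within the scatter, but neither of its groups is involved in the present change, and no measured pair makes this exchange. For the measured compounds named here, nothing measured so far points to a step beyond the scatter in this assay, and none is expected.

The estimate is set somewhat toward compound 2 at 1.42 h, whose 1-acetylpyrrolidin-3-yl group holds a carbonyl, as the entering group does. The expected step is a 1.5-fold lower number from compound 3 to compound 4 (0.16 log units; within the scatter). For compound 4 the estimated value is 1.7 h, with an expected range of 0.9 h to 3.2 h.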

Compound 4, half-life: 2.92 h
Beside the measured number, compound 4's estimate is 1.7-fold (0.23 log units) below it; the range from low to high includes it.
By their numbers in this assay, from the lowest: compounds 1, 2, 3 and 4 (each within the scatter of the next, the first and the last beyond it).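

In this assay, among these compounds, the exchange gives a 1.2-fold higher number from compound 3 to compound 4 (0.07 log units; within the scatter), the first measured step at this place on an aromatic carbon, meta to a large group. The read-out therefore shows no step beyond the scatter when 1-methylpiperidin-4-yl, with one hetero atom in its six-membered non-aromatic ring, gives way to (morpholin-4-yl)carbonyl, with two hetero atoms in its ring and a carbonyl joining that ring to the aromatic carbon. No measurement here bears on why the half-life stays within the scatter across this exchange.

The compounds shown leave open whether other groups at this place, such as a carboxylic acid, an open-chain dimethylamide or a piperidin-1-ylcarbonyl group, would also stay within the scatter of compound 3 and compound 4. They also leave open whether (morpholin-4-yl)carbonyl or 1-methylpiperidin-4-yl would give a similar half-life on another carbon of the same aromatic ring, and whether a change to the amino group or the pyridine of the shared core would alter this picture.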